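The source may report more compounds than this note shows. Statements on the series, on what has been measured and on what is new or still open speak of the compounds shown alone.

Compound 1 `COc1ccc(-c2cc3c(cn2)[nH]c(=O)n3-c2cc(OC)c(OC)c(OC)c2)cc1`: 930 nM
Compound 2 `COc1ccc(-c2cc3c(cn2)[nH]c(=O)n3-c2cc(OC)c(OC)c(OC)c2)cc1F`: 730 nM
Compound 3 `COc1ccc(-c2cc3c(cn2)[nH]c(=O)n3-c2cc(OC)c(OC)c(OC)c2)cc1O`: 240 nM

These values come from a functional assay on A2780 cells (Homo sapiens) for antiproliferative activity, read by MTT assay, with a stated time of 48 h; on this read-out higher numbers stand for weaker inhibition and lower numbers for stronger inhibition. Compound 1 stands at the weak end of this small set. Its number cannot be told apart from that of compound 2, given a 1.3-fold lower number from compound 1 to compound 2 (0.11 log units; within the scatter), while a 3.9-fold lower number from compound 1 to compound 3 (0.59 log units; beyond the scatter) is a modest gain.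

Compound 4 `CCOc1ccc(-c2cc3c(cn2)[nH]c(=O)n3-c2cc(OC)c(OC)c(OC)c2)cc1F` has not yet been measured. It differs from compound 1 at one place, on an aromatic carbon next to the ring nitrogen, where 4-ethoxy-3-fluorophenyl stands in place of 4-methoxyphenyl (4-ethoxy-3-fluorophenyl in place of 4-methoxyphenyl on an aromatic carbon).

The fluoro part of this change has a direct precedent in the step to compound 2, which stayed within the scatter. Among the compounds with values here, the a 3.0-fold lower number from compound 2 to compound 3 (0.48 log units; beyond the scatter) also lies beyond the scatter, but compound 4 carries no hydroxy group, so this step and the one from compound 1 to compound 3 say little about it. Within the data shown here, no measured step covers ethoxy in place of methoxy, and this gap is the main uncertainty. No step beyond the scatter is therefore expected in this assay, in either direction, though the range must stay wide.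

The estimate means an expected 1.1-fold lower number from compound 1 to compound 4 (0.04 log units; within the scatter).

For compound 4 the expected value is 850 nM, with an estimated range of 350 nM to 2200 nM.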

Compound 4, half-maximal inhibitory concentration: 4330 nM
For compound 4 the middle estimate is 5.1-fold (0.71 log units) below the measured one, outside the stated range (above it).
By their numbers in this assay, from the lowest: compound 3; then compounds 2 and 1 (each within the scatter of the next); then compound 4.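

The clearest reading comes from the one-place change of methyl in place of hydrogen on the saturated chain carbon bound to an oxygen on an aromatic ring: in this assay it gives a 5.9-fold higher number from compound 2 to compound 4 (0.77 log units; beyond the scatter), so this position, where the fluoro change stayed within the scatter, responds clearly to a small extension of the alkoxy chain. Within the data shown here, the full replacement of 4-methoxyphenyl by 4-ethoxy-3-fluorophenyl gives a 4.7-fold higher number from compound 1 to compound 4 (0.67 log units; beyond the scatter), and the comparison with the 3-hydroxy-4-methoxyphenyl group gives an 18-fold higher number from compound 3 to compound 4 (1.26 log units; beyond the scatter), which shows that the group on this carbon can move activity in either direction and over a wider span than the earlier compounds revealed. Nothing available here accounts for the loss that comes with the ethoxy group.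

As far as these compounds go, it remains open whether ethoxy has the same effect with hydrogen in place of the fluoro group, and whether a longer chain such as propoxy would lower activity further. The compounds shown also leave open how this position would respond to an amine or a carboxylic acid at the end of the chain.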